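Cytotoxicity notes: acetyl to cyano on the ethenyl chain

The source may report more compounds than this note shows. Statements on the series, on what has been measured and on what is new or still open speak of the compounds shown alone.

Two members of the series have been read so far in an ADME assay on TZM cells (Homo sapiens) for cytotoxicity, read by XTT assay, with a stated time of 4 days; on this read-out higher numbers stand for lower toxicity in this test and lower numbers for higher toxicity in this test: compound 1 (`Cc1cc(/C=C/C#N)cc(C)c1Oc1cc(Nc2ccc(C#N)cc2)c([N+](=O)[O-])cc1[N+](=O)[O-]`) and compound 2 (`CC(=O)/C=C/c1cc(C)c(Oc2cc(Nc3ccc(C#N)cc3)c(N)cc2[N+](=O)[O-])c(C)c1`). Compound 1 gives > 43900 nM, which is a limit of the assay and not a number. Going by the values given here, compound 2 gives 5880 nM, the only true number.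

Compound 3 (`Cc1cc(/C=C/C#N)cc(C)c1Oc1cc(Nc2ccc(C#N)cc2)c(N)cc1[N+](=O)[O-]`) is still unread in this assay. It differs from compound 2 in one place: cyano in place of acetyl on a double-bonded chain carbon bound to a double-bonded chain carbon. In short, the exchange takes 2-acetylethenyl to 2-cyanoethenyl.

Among the compounds with values here, no measured pair shows this exchange, so its size has no direct precedent. The expectation therefore stays anchored on compound 2 at 5880 nM, with a small shift towards lower toxicity that may not clear the usual scatter. The expected step is a 1.5-fold higher number from compound 2 to compound 3 (0.18 log units; within the scatter). For compound 3 the estimated value is 9000 nM, with an expected range of 3500 nM to 30000 nM.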

Compound 3, half-maximal cytotoxic concentration: > 47000 nM
Compound 3 was reported as a limit; the forecaster's own chance of this, stated with the estimate: 20%; middle value at least 5.2-fold (0.71 log units) away from the limit.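

In this assay, going by these compounds alone, cyano in place of acetyl on a double-bonded chain carbon bound to a double-bonded chain carbon gives an at least 7.9-fold higher number from compound 2 to compound 3 (0.90 log units; beyond the scatter), the first readable step and one that shows this place on the chain can move the read-out beyond the scatter. Compound 3 gives > 47000 nM, which is a limit of the assay and not a number. The step from compound 1 to compound 3, amino in place of nitro on an aromatic carbon, cannot be read, as both of its ends are limits.

The compounds shown leave open whether the lower number of compound 2 belongs to acetyl alone or would also appear with another carbonyl group at the same place, such as a carboxylic acid or a methyl ester, or with a longer chain ending in acetyl. They also leave open what amino in place of nitro does on an aromatic carbon, as a nitro partner of compound 2 carrying the 2-acetylethenyl chain would be needed to give that exchange a number.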